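Head group swap on the diaryl ether series

A few compounds are considered here, and "the series" means these few. Any claim that something is new, unique, unknown or untested is made for them only; others in the source may bear on it.

Compounds measured in a functional assay for agonist activity at Free fatty acid receptor 1 (Homo sapiens), read by FLIPR, in the presence of a further agent that is not named here (on this read-out lower numbers stand for an effect already at smaller amounts and higher numbers for an effect only at larger amounts of compound), so far:
compound 1, `O=C1NC(=O)C(Cc2ccc(Oc3ccc(Cl)cc3Cl)cc2)O1`, 4020 nM
compound 2, `O=C1NC(=O)C(Cc2ccc(CCc3ccccc3)cc2)S1`, 1080 nM
compound 3, `O=C1NC(=O)C(Cc2ccc(OCc3ccccc3)cc2)S1`, 6180 nM

Compound 1 sits second highest of the three numbers in this assay. Its nearest neighbour is compound 3, whose value lies within the usual scatter of that of compound 1, so no order between the two can be read. Among the compounds with values here, compound 2 stands furthest away, with a number that is lower than that of compound 1 by more than the scatter; no single-point step links it to compound 1, so only the two values themselves are on hand.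

Compound 4, `O=C1CC(Cc2ccc(Oc3ccc(Cl)cc3Cl)cc2)C(=O)N1`, has not been measured. It differs from compound 1 in one place: 2,5-dioxopyrrolidin-3-yl in place of 2,4-dioxo-1,3-oxazolidin-5-yl on a saturated chain carbon bound to an aromatic carbon. Within the data shown here, no measured pair in the set shows this change, so its size in this assay is not established. The step from compound 1 to compound 4 is expected to run toward a higher number, beyond the scatter, estimated as a 2.5-fold higher number from compound 1 to compound 4 (0.40 log units; beyond the scatter). Compound 4 is therefore estimated at 10000 nM, within a range of 3000 nM to 35000 nM.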

Compound 4, half-maximal effective concentration: 6450 nM
Compound 4: the middle estimate sits 1.6-fold (0.19 log units) above what was measured; measured number inside the range.
By their numbers in this assay, from the lowest: compound 2; then compounds 1, 3 and 4 (each within the scatter of the next).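

Within the data shown here, the first single-place step shows that, in this assay, replacing 2,4-dioxo-1,3-oxazolidin-5-yl with 2,5-dioxopyrrolidin-3-yl on a saturated chain carbon bound to an aromatic carbon gives a 1.6-fold higher number from compound 1 to compound 4 (0.21 log units; within the scatter), so no change can be read from this swap. The ring of the head group at this position can therefore differ in its hetero atoms, and the group can go from 3 to 2 hydrogen-bond acceptors, with both compounds still within the scatter of each other. No supporting data bear on why the two head groups read alike.

Going by these compounds, it remains open whether a carboxylic acid at this position would read the same way as these two rings. On these data alone, it is also open whether this exchange gives a similar step on the other side chains, such as that of compound 2.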